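The source may hold more compounds than are shown below. What is called first, only, known or untested is meant among the compounds shown, and "the series" means these compounds.

Compound 1 `N/N=C\c1cc(=O)oc2cc(OCc3ccccc3)ccc12` gives 9740 nM in a functional assay, read by spectrophotometry, with a stated time of 3 min; a higher number here means a weaker inhibitor, a lower number a stronger inhibitor. Compound 2 `O=c1cc(/C=N\c2ccc(O)cc2)c2c(OCc3ccccc3)cc(OCc3ccccc3)cc2o1` gives 3570 nM. Compound 3 `O=c1cc(/C=N\Nc2ccccc2)c2ccc(OCc3ccccc3)cc2o1` gives 13200 nM.

Compound 2 gives the lowest number of the three, and its gaps to compound 1 and to compound 3 both go beyond the scatter. Compound 4 `O=c1cc(/C=N\Nc2ccc([N+](=O)[O-])cc2)c2c(OCc3ccccc3)cc(OCc3ccccc3)cc2o1` differs from compound 2 in one place: (4-nitrophenyl)amino in place of 4-hydroxyphenyl on a double-bonded nitrogen. Among the measured compounds shown here, the only measured step touching this part of the molecule is a 1.4-fold higher number from compound 1 to compound 3 (0.13 log units; within the scatter), and that change is not the same as the one here. For the measured compounds named here, no measured step shows what this exchange does, so no step beyond the scatter is expected in either direction. Compound 4 is therefore expected to give about 5000 nM, between 1500 nM and 15000 nM, which means a step of a 1.4-fold higher number from compound 2 to compound 4 (0.15 log units; within the scatter).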

Compound 4, half-maximal inhibitory concentration: 15500 nM
Compound 4: the middle estimate sits 3.1-fold (0.49 log units) below what was measured; measured number outside the range, above it.
By their numbers in this assay, from the lowest: compound 2; then compounds 1, 3 and 4 (each within the scatter of the next).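

On a double-bonded nitrogen of the shared core, (4-nitrophenyl)amino in place of 4-hydroxyphenyl gives a 4.3-fold higher number from compound 2 to compound 4 (0.64 log units; beyond the scatter) in this assay. This is the first single change shown to go beyond the scatter, so the group at this position can alter the number measured. No available evidence accounts for this step. The exchange adds an amino nitrogen and replaces hydroxy with nitro at once, leaving the share of each open. Also open, as far as these compounds go, is how 4-aminophenyl or 4-carboxyphenyl would behave on this nitrogen.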